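Amide for sulfonamide on the longer chain

The compounds below may be only part of what the source reports. "The series", "measured", "known", "first", "only" and "open" are said of these compounds alone.

Measured compounds:
compound 1 `O=S(=O)(NCCCNc1nccc(-c2c(-c3cccc(F)c3)nc3sccn23)n1)c1ccc(Cl)cc1`: 5900 nM
compound 2 `Cc1ccc(S(=O)(=O)NCCNc2nccc(-c3c(-c4cccc(F)c4)nc4sccn34)n2)cc1`: 15400 nM

In a functional assay on A-375 cells (Homo sapiens) for cytotoxicity, read by MTT assay (a lower number here means a stronger inhibitor, a higher number a weaker inhibitor), compound 2 gives the highest of the two numbers; its nearest neighbour is compound 1, and the step of a 2.6-fold higher number from compound 1 to compound 2 (0.42 log units; beyond the scatter) lies beyond the scatter. Compound 3 `O=C(NCCCNc1nccc(-c2c(-c3cccc(F)c3)nc3sccn23)n1)c1ccc(Cl)cc1` differs from compound 2 by (((4-chlorophenyl)carbonyl)amino)methyl in place of ((4-methylphenyl)sulfonyl)amino on a saturated chain carbon, two bonds along the chain from a nitrogen on an aromatic ring. Within the data shown here, this change restores the chain length and the 4-chlorophenyl group of compound 1 while exchanging the sulfonyl for a carbonyl, a change on which no measured step bears directly. Among the measured compounds shown here, the only step that informs the expectation is a 2.6-fold higher number from compound 1 to compound 2 (0.42 log units; beyond the scatter), which ran in the other direction when the chlorophenyl sulfonamide on the longer chain was replaced. A modest lowering of the number from compound 2 to compound 3 is therefore expected, roughly back toward compound 1, as a 2.4-fold lower number from compound 2 to compound 3 (0.37 log units; beyond the scatter). Compound 3 is expected to give 6500 nM, with a range of 2000 nM to 20000 nM.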

Compound 3, half-maximal inhibitory concentration: 13700 nM
Compound 3: the middle estimate sits 2.1-fold (0.32 log units) below what was measured; measured number inside the range.
By their numbers in this assay, from the lowest: compound 1; then compounds 3 and 2 (each within the scatter of the next).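

Carbonyl in place of sulfonyl on the amine nitrogen can now be read on its own, with the longer chain and 4-chlorophenyl group held fixed: in this assay it gives a 2.3-fold higher number from compound 1 to compound 3 (0.37 log units; beyond the scatter) and so is a modest step beyond the scatter. The other step, a 1.1-fold lower number from compound 2 to compound 3 (0.05 log units; within the scatter), lies within the scatter, so compound 2 and compound 3 cannot be told apart here despite carrying different groups at this position. No evidence is available on what underlies either step.

The compounds shown do not separate chain length from the change of 4-methylphenyl to 4-chlorophenyl within the step of a 2.6-fold higher number from compound 1 to compound 2 (0.42 log units; beyond the scatter). Also open, from the compounds shown here alone, is how a urea on the amine nitrogen or a longer chain carrying the sulfonamide would read in this assay.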